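A few compounds are considered here, and "the series" means these few. Any claim that something is new, unique, unknown or untested is made for them only; others in the source may bear on it.

Measured compounds: compound 1, `Cn1cncc1CN1CC(N(Cc2cccc(-n3cccc3)c2)S(=O)(=O)c2ccccn2)Cc2cc(C#N)ccc21`, in an ADME assay on Caco-2 cells (Homo sapiens) for permeability, in the apical to basolateral direction (on this read-out lower numbers stand for lower permeability and higher numbers for higher permeability), gives 2.3 10^-6 cm/s; compound 2, `CCCC(=O)N1CCC(CN(C2Cc3cc(C#N)ccc3N(Cc3cncn3C)C2)S(=O)(=O)c2ccccn2)CC1`, gives 0.5 10^-6 cm/s.

Within the data shown here, compound 2 stands lowest of the two numbers, its only neighbour being compound 1 through a 4.6-fold lower number from compound 1 to compound 2 (0.66 log units; beyond the scatter). Compound 3, `C=C(C)C(=O)N1CCC(CN(C2Cc3cc(C#N)ccc3N(Cc3cncn3C)C2)S(=O)(=O)c2ccccn2)CC1`, differs from compound 2 by 1-methylethenyl in place of propyl on a carbonyl carbon. Among the measured compounds shown here, no measured step touches the carbonyl carbon: the single known step, a 4.6-fold lower number from compound 1 to compound 2 (0.66 log units; beyond the scatter), exchanged the group on a saturated chain carbon bound to a sulfonamide nitrogen, and so says nothing about this position. On that thin evidence a step within the scatter is expected, no change at the digits printed from compound 2 to compound 3 (within the scatter). Compound 3 is therefore estimated at 0.5 10^-6 cm/s, in the range 0.25 10^-6 cm/s to 1 10^-6 cm/s.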

Compound 3, apparent permeability: 0.5 10^-6 cm/s
Beside the measured number, compound 3's estimate shows no gap at the digits printed, within the range that was stated.
By their numbers in this assay, from the lowest: compounds 2 and 3 (each within the scatter of the next); then compound 1.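

Among these compounds, at the carbonyl carbon, the first reading of this position in this assay is no change at the digits printed from compound 2 to compound 3 (within the scatter) with 1-methylethenyl in place of propyl, so this exchange leaves the number unmoved. The second step, a 4.6-fold lower number from compound 1 to compound 3 (0.66 log units; beyond the scatter) for the larger exchange on the saturated chain carbon, shows that the gap first seen with compound 2 holds with either group on the carbonyl carbon. Nothing available here accounts for these numbers.

On these data alone, what stays open is how the number would respond to an amine, a carboxylic acid or a longer chain on the carbonyl carbon.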